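Vinyl in place of chloromethyl on the amide carbonyl

The source may report more compounds than this note shows. Statements on the series, on what has been measured and on what is new or still open speak of the compounds shown alone.

Compound 3 `COc1ccc(CN(C(=O)CCl)c2cc(OC)c(OC)c(OC)c2)cc1O` gives 210 nM in a functional assay on KYSE-450 cells (Homo sapiens) for inhibition, read by MTT assay, with a stated time of 48 h (a higher number here means a weaker inhibitor, a lower number a stronger inhibitor), the highest number of the three measured. Compound 1 `CC/C=C/C(=O)N(Cc1ccc(OC)c(O)c1)c1cc(OC)c(OC)c(OC)c1`, with but-1-en-1-yl on the carbonyl carbon, gives 72 nM, and compound 2 `CCC(=O)N(Cc1ccc(OC)c(O)c1)c1cc(OC)c(OC)c(OC)c1`, with ethyl there, gives 98 nM; the steps were a 2.9-fold higher number from compound 1 to compound 3 (0.46 log units; beyond the scatter) and a 2.1-fold higher number from compound 2 to compound 3 (0.33 log units; beyond the scatter), both modest yet beyond the scatter. Compound 4 `C=CC(=O)N(Cc1ccc(OC)c(O)c1)c1cc(OC)c(OC)c(OC)c1` is unmeasured and differs from compound 3 in one place: vinyl in place of chloromethyl on a carbonyl carbon. Vinyl shares with the but-1-en-1-yl of compound 1 a double bond outside aromatic rings, and both measured steps place compound 3 at the weaker end, so in this assay a lower number is expected for compound 4, roughly a 2.3-fold lower number from compound 3 to compound 4 (0.37 log units; beyond the scatter), back toward compounds 1 and 2. Compound 4 is therefore estimated at 90 nM, within 40 nM to 200 nM.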

Compound 4, half-maximal inhibitory concentration: 160 nM
Estimate against measurement, compound 4: 1.8-fold (0.25 log units) below, within the range that was stated.
By their numbers in this assay, from the lowest: compounds 1, 2, 4 and 3 (each within the scatter of the next, the first and the last beyond it).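

In this assay, vinyl on the carbonyl carbon is not separated from chloromethyl (a 1.3-fold lower number from compound 3 to compound 4 (0.12 log units; within the scatter)) or from ethyl (a 1.6-fold higher number from compound 2 to compound 4 (0.21 log units; within the scatter)). Only but-1-en-1-yl is separated from vinyl (a 2.2-fold higher number from compound 1 to compound 4 (0.35 log units; beyond the scatter)), so a double bond outside aromatic rings does not alone fix the number: compound 1 and compound 4 both carry one. Nothing on hand accounts for these steps.

Open, as far as these compounds go, is whether an amine or a carboxylic acid on the carbonyl carbon would move the number beyond the scatter from compound 4. Also open, from the compounds shown here alone, is whether a longer chain on the double bond would follow compound 1.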